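Notes on the Side-Chain Change from Compound 2 to Compound 3

The source may report more compounds than this note shows. Statements on the series, on what has been measured and on what is new or still open speak of the compounds shown alone.

Among the measured compounds shown here, the series so far holds compound 1 (`C=C1CC[C@H]2[C@@](C)(CC[C@@H](O)[C@@]2(C)C(=O)OC)[C@@H]1CCC1=CCOC1=O`) and compound 2 (`C=C1CC[C@H]2[C@@](C)(CC[C@@H](O)[C@@]2(C)C(=O)OCc2ccccn2)[C@@H]1CCC1=CCOC1=O`). In a functional assay on NIH3T3 cells (Mus musculus) for inhibition, read by MTT assay, with a stated time of 72 h (on this read-out lower numbers stand for stronger inhibition and higher numbers for weaker inhibition), compound 1 gives 60600 nM. For the measured compounds named here, compound 2 gives 79800 nM, which stands within the scatter of the only other number available.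

Compound 3 (`C=C1CC[C@H]2[C@@](C)(CC[C@@H](O)[C@@]2(C)C(=O)OCc2ccccn2)[C@@H]1/C=C/C1=CCOC1=O`) has not yet been measured. It departs from compound 2 as follows: a group of 8 heavy atoms (6 carbon, 2 oxygen; one five-membered non-aromatic ring with 1 hetero atom) in place of a group of 8 heavy atoms (6 carbon, 2 oxygen; one five-membered non-aromatic ring with 1 hetero atom), on a saturated ring carbon.

Going by the values given here, only one measured step exists: a 1.3-fold higher number from compound 1 to compound 2 (0.12 log units; within the scatter). Among the compounds with values here, that step put pyridin-2-yl in place of hydrogen on a saturated chain carbon bound to an oxygen next to a carbonyl group, which is a different place from the one that changes now. Within the data shown here, the series holds no measured step at the saturated ring carbon, so the size of this change cannot be read from the data. With no evidence for a real shift, no step beyond the scatter is expected in this assay, and the expected step is a 1.3-fold lower number from compound 2 to compound 3 (0.12 log units; within the scatter). For compound 3 the estimated value is 60000 nM, with an expected range of 25000 nM to 120000 nM.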

Compound 3, half-maximal inhibitory concentration: 80200 nM
Estimate against measurement, compound 3: 1.3-fold (0.13 log units) below; the measured number falls inside the stated range.
By their numbers in this assay, from the lowest: compounds 1, 2 and 3 (each within the scatter of the next).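

In this assay, the one double bond outside aromatic rings that the entering group adds to the group on the saturated ring carbon gives a 1.0-fold higher number from compound 2 to compound 3 (0.00 log units; within the scatter) and so no step beyond the scatter, with the heavy-atom count, hydrogen-bond donors and hydrogen-bond acceptors the same in both groups. Among the compounds shown here, this is the first measured step at this position, and it shows that compound 3 keeps a number within the scatter of compound 2 when this group carries the extra double bond, just as the earlier step at the other place stayed within the scatter. No measurement available here bears on why the number holds at this position, and these compounds support no reading beyond the size of the step itself.

Still open, from the compounds shown here alone, is whether a larger replacement on the saturated ring carbon, such as a longer chain in place of the present link or a carboxylic acid in place of the five-membered ring, would give a step beyond the scatter. Also open, going by these compounds, is whether the extra double bond would read the same on compound 1, which lacks the pyridin-2-yl group.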